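Cyclohexyl for phenyl on a weak growth inhibitor

The compounds below may be only part of what the source reports. "The series", "measured", "known", "first", "only" and "open" are said of these compounds alone.

In an ADME assay on BaF3 cells (Mus musculus) for inhibition, read by CellTiter-Glo, with a stated time of 72 h (a higher number here means a weaker inhibitor of growth, a lower number a stronger inhibitor of growth), compound 2 (`Cc1ccc(Nc2ncc3c(n2)N(c2ccccc2)C(=O)N(c2cc(NC(=O)c4ccc(C)c(C(F)(F)F)c4)ccc2C)C3)cn1`) gives 3300 nM as the highest of three numbers, while compound 3 (`Cc1ccc(Nc2ncc3c(n2)N(C)C(=O)N(c2cc(NC(=O)c4ccc(CN5CCC(N(C)C)C5)c(C(F)(F)F)c4)ccc2C)C3)cn1`) gives 636 nM and compound 1 (`Cc1ccc(Nc2ncc3c(n2)N(C)C(=O)N(c2cc(NC(=O)c4ccc(-n5cccc5)c(C(F)(F)F)c4)ccc2C)C3)cn1`) gives 317 nM on the lower side. The move to compound 4 (`Cc1ccc(Nc2ncc3c(n2)N(C2CCCCC2)C(=O)N(c2cc(NC(=O)c4ccc(C)c(C(F)(F)F)c4)ccc2C)C3)cn1`) is cyclohexyl in place of phenyl on an amide-type nitrogen in a ring and puts cyclohexyl in place of phenyl on an amide-type nitrogen in a ring. Among the measured compounds shown here, the one measured step, a 2.0-fold higher number from compound 1 to compound 3 (0.30 log units; within the scatter) in this assay, concerns another place and bears on this change only as a sense of size. For the measured compounds named here, no measured step changes the group on this nitrogen, so no shift beyond the scatter is expected. The estimated step is a 1.1-fold lower number from compound 2 to compound 4 (0.04 log units; within the scatter) and would stay within the scatter. Compound 4 is expected at 3000 nM as a central estimate, with a range of 1000 nM to 9000 nM around it.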

Compound 4, concentration for 50% growth inhibition: > 5000 nM
Compound 4: no number, only a limit; the forecaster's own chance of this, stated with the estimate: 10%; middle value at least 1.6-fold (0.22 log units) away from the limit.
By their numbers in this assay, from the lowest: compounds 1 and 3 (each within the scatter of the next); then compound 2. At a limit, above all of these: compound 4.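

In this assay, compound 4 gives > 5000 nM, which is a limit of the assay and not a number. This is the first step shown that changes the group on this amide-type nitrogen, and it can be read only as a floor: an at least 1.5-fold higher number from compound 2 to compound 4 (0.18 log units; that floor lies within the scatter). Cyclohexyl in place of phenyl brings no lower number here, but the true size of the step stays unknown.

From the compounds shown here alone, whether a ring carrying an amine, such as piperidinyl, or a longer chain such as hydroxyethyl, would be tolerated on this nitrogen remains open.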